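Working notes on the step from compound 1 to compound 4

The source may hold more compounds than are shown below. What is called first, only, known or untested is meant among the compounds shown, and "the series" means these compounds.

Compound 1 `CN(Cc1ccccc1F)C(=O)CNC(=O)c1ccc(S(C)(=O)=O)c([N+](=O)[O-])c1` was tested in an assay on isolated protein for inhibition of vitamin D3 receptor (Homo sapiens), read by fluorescence polarization; on this read-out higher numbers stand for weaker inhibition and lower numbers for stronger inhibition. In this assay compound 1 gives only a limit of the assay, > 60000 nM, and not a number. Two further members of the series sit at the same limit. Compound 2 `CC1CCN(C(=O)CN(C)C(=O)c2ccc(S(C)(=O)=O)c([N+](=O)[O-])c2)CC1` in this assay gives > 60000 nM, a limit and not a number. Compound 3 `CC1CCN(C(=O)CCNC(=O)c2ccc(S(C)(=O)=O)c([N+](=O)[O-])c2)CC1` in this assay gives > 60000 nM, again a limit rather than a number. Compound 1 therefore stands at the limit of > 60000 nM in this assay, at which 3 of the 3 values shown sit, and no ordering among compound 1, compound 2 and compound 3 can be read from these figures.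

Compound 4 `CN(Cc1cccc(F)c1)C(=O)CNC(=O)c1ccc(S(C)(=O)=O)c([N+](=O)[O-])c1` has not yet been measured in this assay. It differs from compound 1 by 3-fluorophenyl in place of 2-fluorophenyl on a saturated chain carbon bound to an amide-type nitrogen. For the measured compounds named here, no step between two measured compounds is available, and none of the three measured values is a number, so no direction for this change can be drawn from the series itself. The expected step that the limit leaves unreadable from compound 1 to compound 4 amounts to nothing beyond the scatter, with the result most likely reported again as a limit. For compound 4 the estimated value in this assay is 100000 nM, with a range from 30000 nM to 300000 nM.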

Compound 4, half-maximal inhibitory concentration: > 60000 nM
Compound 4: no number, only a limit (the forecaster's own chance of this, stated with the estimate: 90%); the middle value lies beyond the limit too.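

In this assay compound 4 gives > 60000 nM, a limit of the assay and not a number. No step from compound 1 to compound 4 can be read, and the series stands as follows: the limit of > 60000 nM in this assay, at which 4 of the 4 values shown sit.

The compounds shown leave open whether 3-fluorophenyl in place of 2-fluorophenyl changes the read-out at all, and what actual number any of these compounds would give.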